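The compounds below may be only part of what the source reports. "The series", "measured", "known", "first", "only" and "open" are said of these compounds alone.

Measured compounds:
compound 1 `O=C(CN1CCN(c2nnc(Cc3ccncc3)c3ccccc23)CC1)Nc1cccc(Br)c1` gives 1350 nM
compound 2 `O=C(CN1CCN(c2nnc(Cc3ccccc3)c3ccccc23)CC1)Nc1ccc(F)c(F)c1` gives 9510 nM

In a functional assay on HT-29 cells (Homo sapiens) for cytotoxicity, read by MTT assay, with a stated time of 72 h (on this read-out higher numbers stand for weaker inhibition and lower numbers for stronger inhibition), compound 1 gives 1350 nM, the lowest of the two numbers in hand. Compound 2 gives 9510 nM, a higher number, and the gap between compound 1 and compound 2 lies beyond the scatter. Among the measured compounds shown here, compound 2 differs from compound 1 in more than one place, so no single step connects them, and the two values show only that compound 1 is the stronger inhibitor of the pair.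

Compound 3 `Cc1cccc(Cl)c1NC(=O)CN1CCN(c2nnc(Cc3ccncc3)c3ccccc23)CC1` differs from compound 1 in one place: 2-chloro-6-methylphenyl in place of 3-bromophenyl on an amide-type nitrogen. For the measured compounds named here, no measured pair carries this change, so nothing in the numbers speaks for its direction. The step from compound 1 to compound 3 is expected to be small, a 1.5-fold higher number from compound 1 to compound 3 (0.17 log units; within the scatter), leaning toward a somewhat higher number but likely within the scatter. Compound 3 is estimated at 2000 nM, within a range of 700 nM to 6000 nM.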

Compound 3, half-maximal inhibitory concentration: 22600 nM
Beside the measured number, compound 3's estimate is 11-fold (1.05 log units) below it; the whole stated range lies below it.
By their numbers in this assay, from the lowest: compound 1; then compound 2; then compound 3.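

In this assay the group on the amide-type nitrogen proves to be a sensitive position: 2-chloro-6-methylphenyl in place of 3-bromophenyl gives a 17-fold higher number from compound 1 to compound 3 (1.22 log units; beyond the scatter) and thus much weaker inhibition on the same core. Among the compounds shown here, this is the first single-place step, so the response to this position can now be read on its own, and here it lies beyond the scatter. Nothing at hand accounts for the size of this step.

A single step cannot separate the part played by the chlorine and the methyl from that of losing the bromine. On these data alone, how an unsubstituted phenyl or a cyclohexyl group on the same nitrogen would read remains open, as does whether the step holds on other cores.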